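The compounds below may be only part of what the source reports. "The series", "measured", "known", "first", "only" and "open" are said of these compounds alone.

Working notes on the series. Compound 1 `CS(=O)(=O)c1ccc(-c2nc3ccc[nH]c-3n2)cc1` gives 18 mg/kg in a functional assay on the whole organism with Canis familiaris (Canis lupus familiaris) as the target; on this read-out lower numbers stand for an effect already at smaller amounts and higher numbers for an effect only at larger amounts of compound. Compound 2 `COc1cc(S(C)(=O)=O)ccc1-c1nc2ccc[nH]c-2n1` carries methoxy in place of hydrogen on an aromatic carbon; in this assay compound 2 gives 0.4 mg/kg, and the step of a 45-fold lower number from compound 1 to compound 2 (1.65 log units; beyond the scatter) follows. Compound 3 `COc1ccc(-c2nc3cc[nH]cc-3n2)cc1` rests on a different core; the difference between the two cores is not broken down here. In this assay compound 3 gives 1.7 mg/kg. Compound 4 `COc1ccc(-c2nc3cc[nH]cc-3n2)cc1OC` is not yet measured; it differs from compound 3 by methoxy in place of hydrogen on an aromatic carbon. This is the same kind of change as that from compound 1 to compound 2, but the surroundings differ: there the entering methoxy sat ortho to a group of 9 heavy atoms and meta to a methylsulfonyl group, here it sits ortho to a methoxy group and meta to a group of 9 heavy atoms. Because the large step of a 45-fold lower number from compound 1 to compound 2 (1.65 log units; beyond the scatter) was seen on another core and in other surroundings, a smaller step of a 2.8-fold lower number from compound 3 to compound 4 (0.45 log units; beyond the scatter) is expected. Compound 4 is estimated at 0.6 mg/kg in this assay.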

Compound 4, dose for half-maximal effect: 0.4 mg/kg
The estimate for compound 4 lay 1.5-fold (0.18 log units) above the measured number; measured number inside the range.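

In this assay the new step reads a 4.3-fold lower number from compound 3 to compound 4 (0.63 log units; beyond the scatter), so the direction seen on the core of compound 1 recurs on the core of compound 3. The size of the step does not carry over from one core to the other: the same change on two cores in this assay, a 45-fold lower number (1.65 log units; beyond the scatter) from compound 1 to compound 2 and a 4.3-fold lower number (0.63 log units; beyond the scatter) from compound 3 to compound 4, 11-fold (1.02 log units) apart, beyond the scatter of two such steps With one pair on each core and the entering methoxy in different surroundings, these data cannot separate the effect of the core from that of the surroundings, and they set no rule for other cores.

As far as these compounds go, it remains open how the number would move with an amine, a carboxylic acid or a longer alkoxy chain in place of the entering methoxy. From the compounds shown here alone, it also remains open whether such a group would show the same difference between the two cores.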